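This account rests on a few compounds, and the source may have more. Where it says the series, first, only, none or still open, it means among the compounds named here.

Measured so far:
Compound 1 `O=C(CCCCCCc1ccc(Cl)cc1)N1CCCC1`: in an assay on HEK293 cells for inhibition of N-acylethanolamine-hydrolyzing acid amidase (Rattus norvegicus), read by LC-MS, with a stated time of 30 min (on this read-out lower numbers stand for stronger inhibition and higher numbers for weaker inhibition), compound 1 gives 34500 nM.
Compound 2 `Cc1ccccc1-c1ccc(CCC(=O)N2CCCC2)cc1`: in this assay compound 2 gives > 100000 nM, which is a limit of the assay and not a number.

Within the data shown here, compound 2 therefore stands at the weak end of what is known: its result is the limit of > 100000 nM in this assay, at which 1 of the 2 values shown sits, so only one of the two compounds, compound 1, has a measured number at all. Among the measured compounds shown here, no two measured compounds differ in a single place, so no measured step is available to guide the next change.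

Compound 3 `Cc1cccc(-c2ccc(CCC(=O)N3CCCC3)cc2)c1` is built from compound 2 by moving one group: 3-methylphenyl in place of 2-methylphenyl on an aromatic carbon. Since compound 2 shows only a limit, the step cannot be read against any measured change. The step from compound 2 to compound 3 is expected to be a number no higher from compound 2 to compound 3 (the limit leaves the size open), that is, no change beyond the usual scatter. Compound 3 is estimated at 100000 nM, with a range from 30000 nM to 300000 nM.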

Compound 3, half-maximal inhibitory concentration: 16500 nM
Estimate against measurement, compound 3: 6.1-fold (0.78 log units) above, outside the stated range (below it).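

In this assay, replacing 2-methylphenyl with 3-methylphenyl gives an at least 6.0-fold lower number from compound 2 to compound 3 (0.78 log units; beyond the scatter). Among these compounds, the two compounds hold the same atoms, joined differently, so this is the first measured sign that the place of the methyl group on this aromatic ring can change the read-out. Going by these compounds, the true size of the step stays open because compound 2 carries a limit and not a number: the limit of > 100000 nM in this assay, at which 1 of the 3 values shown sits.

On these data alone, it remains open whether the methyl group itself contributes, which a plain phenyl in the same place would help to settle, and whether a 3-chlorophenyl or 3-methoxyphenyl would give a lower or a higher number than compound 3. Compound 1 differs from compound 2 and compound 3 in more than one place, so it cannot show how the chain or the rest of the core contributes.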